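The source may hold more compounds than are shown below. What is called first, only, known or untested is meant among the compounds shown, and "the series" means these compounds.

Measured so far in an ADME assay on HEK293 cells (Homo sapiens) for cytotoxicity, read by CCK-8 assay and cell counting, with a stated time of 2 days; a lower number here means a stronger inhibitor, a higher number a weaker inhibitor: compound 1 `Oc1ccc(-c2cc(-c3cccc(Cl)c3)nc(-c3ccccn3)c2)cc1` gives 25400 nM; compound 2 `Oc1ccc(-c2cc(-c3ccc(Cl)cc3)nc(-c3cccs3)c2)cc1` gives 4520 nM; compound 3 `Oc1ccc(-c2cc(-c3ccc(Cl)cc3)nc(-c3ccsc3)c2)cc1` gives 4860 nM.

Among these three numbers compound 3 stands second highest, with compound 2 nearest and compound 1 furthest away. Compound 4 `Oc1ccc(-c2cc(-c3ccc(Cl)cc3)nc(-c3ccccn3)c2)cc1` is not yet measured; it carries pyridin-2-yl in place of thiophen-3-yl on an aromatic carbon. Within the data shown here, the only measured step at that spot is a 1.1-fold higher number from compound 2 to compound 3 (0.03 log units; within the scatter), a swap of one thiophene isomer for the other, so it says little about a pyridin-2-yl. Among the measured compounds shown here, compound 1 is the only measured compound with a pyridin-2-yl on the aromatic carbon next to the ring nitrogen, and it gives the highest number, though it also differs from compound 3 elsewhere. A step toward higher numbers is therefore expected, estimated as a 2.9-fold higher number from compound 3 to compound 4 (0.46 log units; beyond the scatter). Compound 4 is expected to give about 14000 nM, within 5000 nM to 40000 nM.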

Compound 4, half-maximal inhibitory concentration: 27200 nM
Estimate against measurement, compound 4: 1.9-fold (0.29 log units) below, within the range that was stated.
By their numbers in this assay, from the lowest: compounds 2 and 3 (each within the scatter of the next); then compounds 1 and 4 (each within the scatter of the next).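

In this assay, pyridin-2-yl on this aromatic carbon brings a far larger change than swapping one thiophene isomer for the other: a 5.6-fold higher number from compound 3 to compound 4 (0.75 log units; beyond the scatter) and a 6.0-fold higher number from compound 2 to compound 4 (0.78 log units; beyond the scatter). With pyridin-2-yl in place, the chlorine's position on the phenyl group makes no difference beyond the scatter, at a 1.1-fold higher number from compound 1 to compound 4 (0.03 log units; within the scatter). Nothing measured here explains the shift seen with pyridin-2-yl. Going by these compounds, it remains open whether the ring size or the ring nitrogen sets the change, and how an unsubstituted phenyl or a pyridin-3-yl would read on this carbon.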